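The compounds below may be only part of what the source reports. "The series", "measured", "known", "first", "only" and "open" are said of these compounds alone.

Measured compounds in this series:
- compound 1, `O=C(CCCCC1CCSS1)NCc1cn(CCCCCOc2ccc3ccc(=O)oc3c2)nn1`: 57.2%
- compound 2, `CC(=O)c1cc2ccc(OCCCCCn3cc(CNC(=O)CCCCC4CCSS4)nn3)cc2oc1=O`: 27.4%
- compound 3, `COc1ccc(-c2cc3ccc(OCCCCCn4cc(CNC(=O)CCCCC5CCSS5)nn4)cc3oc2=O)cc1`: 37.1%

All three share the same core and were run in a functional assay on PC-12 cells (Rattus norvegicus) for cytotoxicity, read by MTT assay, with stated times of 3 h and 2 h, tested at 1 uM; on this read-out higher numbers stand for a stronger effect at the one concentration tested and lower numbers for a weaker effect. Compound 3 sits second highest of the three numbers; its step to compound 2 is within the scatter (a number 9.7 percentage points higher from compound 2 to compound 3 (within the scatter)), while against compound 1 the gap is beyond the scatter (a number 20.1 percentage points lower from compound 1 to compound 3 (beyond the scatter)). Compound 1 also stands apart from compound 2 (a number 29.8 percentage points lower from compound 1 to compound 2 (beyond the scatter)).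

Compound 4, `COc1ccc(-c2cc3ccc(OCCCCCn4cc(CNC(=O)CCCCC5CCSS5)nn4)cc3oc2=O)cc1OC`, remains to be measured in this assay. It differs from compound 3 as follows: methoxy in place of hydrogen on an aromatic carbon. The entering group is placed on the 4-methoxyphenyl ring, ortho to a methoxy group and meta to a large group.

Going by the values given here, none of the measured steps touches this position. Among the compounds with values here, the two steps beyond the scatter, from compound 1, both concern replacement of hydrogen on an aromatic carbon of the core, not a change on the pendant ring; the one step involving compound 3 (a number 9.7 percentage points higher from compound 2 to compound 3 (within the scatter)) is within the scatter. There is therefore no measured basis for a shift in either direction, and no step beyond the scatter is expected in this assay.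

For compound 4 a value of 36% is estimated, within 22% to 50%, the expected step being a number 1.1 percentage points lower from compound 3 to compound 4 (within the scatter).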

Compound 4, a percentage reported as activity, at one concentration (the size of the read-out at that concentration, not a potency): 42.2%
Compound 4: middle estimate off by 6.2 percentage points, on the low side, and the stated range covers the measured number.
By their numbers in this assay, from the lowest: compounds 2, 3 and 4 (each within the scatter of the next, the first and the last beyond it); then compound 1.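

Working from the pendant ring, methoxy in place of hydrogen, ortho to a methoxy group and meta to a large group, leaves this assay within the scatter (a number 5.1 percentage points higher from compound 3 to compound 4 (within the scatter)), so this single change is not resolved on this read-out. Measured against acetyl on the shared core, the 3,4-dimethoxyphenyl group gives a separation that the 4-methoxyphenyl group did not give (a number 14.8 percentage points higher from compound 2 to compound 4 (beyond the scatter) against a number 9.7 percentage points higher from compound 2 to compound 3 (within the scatter)), although the second methoxy step itself stays within the scatter, so this separation should not be credited to that group alone; against hydrogen at the same core position, the 3,4-dimethoxyphenyl group still gives a lower number (a number 15 percentage points lower from compound 1 to compound 4 (beyond the scatter)). No measurement available here explains any of these steps.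

With methoxy the only group shown at this position, it remains open whether a hydroxy group, an amine or a carboxylic acid there would produce a step beyond the scatter. Going by these compounds, it is also open whether a longer chain on the oxygen, such as ethoxy or butoxy, would read any differently from methoxy at this single concentration.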